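The source may hold more compounds than are shown below. What is called first, only, known or untested is meant among the compounds shown, and "the series" means these compounds.

Working notes on the series

Among the measured compounds shown here, compound 1 `Cc1cccnc1-c1ccc(C(=O)Nc2ccc(C(C)(C)C)cc2)cc1` gives 11 nM in a functional assay for antagonist activity at transient receptor potential cation channel subfamily V member 1 (Homo sapiens), read by FLIPR (a lower number here means a stronger inhibitor, a higher number a weaker inhibitor), the lowest of the two numbers measured so far. For the measured compounds named here, its only neighbour, compound 2 `CCS(=O)(=O)Nc1cccnc1-c1ccc(C(=O)Nc2ccc(C(C)(C)C)cc2)cc1`, gives 49 nM; the one change between them, (ethylsulfonyl)amino in place of methyl on an aromatic carbon, brought a 4.5-fold higher number from compound 1 to compound 2 (0.65 log units; beyond the scatter).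

Compound 3 `CC(C)(C)c1ccc(NC(=O)c2ccc(-c3ncccc3-c3nn[nH]n3)cc2)cc1` has not yet been measured. It differs from compound 1 as follows: 2H-tetrazol-5-yl in place of methyl on an aromatic carbon. Going by the values given here, the step from compound 1 to compound 2 is the only measured step bearing on this change, since it also replaces the methyl at the same place with a larger group carrying hydrogen-bond donors and acceptors; that step weakened inhibition beyond the scatter. A step of at least that size, in the same direction, is therefore expected for compound 3, as a 9.1-fold higher number from compound 1 to compound 3 (0.96 log units; beyond the scatter). Compound 3 is estimated at 100 nM, with a range from 25 nM to 500 nM.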

Compound 3, half-maximal inhibitory concentration: > 4000 nM
Compound 3: a limit, no number; the forecaster's own chance of this, stated with the estimate: 5%; at least 40-fold (1.60 log units) between middle value and limit.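

Compound 3 stands at a limit in this assay, not at a number: the limit of > 4000 nM in this assay, at which 1 of the 3 values shown sits.

This position, ortho to a large group, does not treat all replacements of methyl alike: the (ethylsulfonyl)amino group gave a 4.5-fold higher number from compound 1 to compound 2 (0.65 log units; beyond the scatter), whereas 2H-tetrazol-5-yl gives an at least 360-fold higher number from compound 1 to compound 3 (2.56 log units; beyond the scatter). The two replacements also part clearly from each other, with an at least 81-fold higher number from compound 2 to compound 3 (1.91 log units; beyond the scatter), which shows that the outcome at this place depends on the group that enters and not only on the loss of methyl.

The compounds shown do not tell whether the ring of 2H-tetrazol-5-yl, its hydrogen-bond donor or some other feature goes with this loss. A carboxylic acid or an amine at the same place would bear on that question.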